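Para-nitro analogue of the dienone series: expected cytotoxicity

The source may hold more compounds than are shown below. What is called first, only, known or untested is meant among the compounds shown, and "the series" means these compounds.

Working notes on three measured phenyl dienones sharing one core and one unmeasured congener. Compound 1 `CC1=C(/C=C/C(=O)/C=C/c2ccccc2)C(C)(C)CCC1O` is the unsubstituted parent; in a functional assay on LNCaP cells (Homo sapiens) for cytotoxicity, read by MTT assay, with a stated time of 72 h (a lower number here means a stronger inhibitor, a higher number a weaker inhibitor), compound 1 gives 5800 nM, the highest of the three numbers. Compound 2 `CC1=C(/C=C/C(=O)/C=C/c2ccccc2F)C(C)(C)CCC1O` gives 2900 nM, and compound 3 `CC1=C(/C=C/C(=O)/C=C/c2cccc(C#N)c2)C(C)(C)CCC1O` gives 1800 nM. The two substituted analogues both sit lower than the parent: a 2.0-fold lower number from compound 1 to compound 2 (0.30 log units; within the scatter), and a 3.2-fold lower number from compound 1 to compound 3 (0.51 log units; beyond the scatter). Between the two substituted compounds the gap is small, a 1.6-fold lower number from compound 2 to compound 3 (0.21 log units; within the scatter).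

Compound 4 `CC1=C(/C=C/C(=O)/C=C/c2ccc([N+](=O)[O-])cc2)C(C)(C)CCC1O` is the parent carrying one further change: nitro in place of hydrogen on an aromatic carbon, the new group standing on the aromatic carbon para to a large group. Among the compounds with values here, no measured pair carries a nitro group, so the bearing steps are only the two aromatic substitutions above, one within the scatter and one modestly beyond it. Both point the same way, toward a lower number. For compound 4 a step of similar size is therefore expected in this assay, a 2.3-fold lower number from compound 1 to compound 4 (0.37 log units; beyond the scatter), with no reason in the data to expect more than the change seen for compound 3. The estimate for compound 4 is 2500 nM, with a range from 1200 nM to 5500 nM.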

Compound 4, half-maximal inhibitory concentration: 4200 nM
Compound 4: middle estimate off by 1.7-fold (0.23 log units), on the low side, within the range that was stated.
By their numbers in this assay, from the lowest: compounds 3, 2, 4 and 1 (each within the scatter of the next, the first and the last beyond it).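

In this assay, nitro on the aromatic carbon para to a large group gives a 1.4-fold lower number from compound 1 to compound 4 (0.14 log units; within the scatter), so this is the first substitution shown at that carbon, and its step does not clear the scatter, unlike a 3.2-fold lower number from compound 1 to compound 3 (0.51 log units; beyond the scatter) for cyano. The lower number seen beyond the scatter for cyano therefore does not extend to every aromatic substitution of compound 1: of the three steps from the parent, only the cyano step lies beyond the scatter, while the fluoro and nitro steps do not. No measurement bears on why the nitro step stays within the scatter.

Compound 3 and compound 4 carry different groups on different aromatic carbons, so the compounds shown cannot separate the effect of the group from that of its place on the ring. Open questions are whether nitrile on the aromatic carbon para to a large group would match the cyano step already seen, and whether an amine or a carboxylic acid on that carbon would move the number beyond the scatter in either direction.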